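Enlarging the Amide Group of Compound 3

The source may hold more compounds than are shown below. What is called first, only, known or untested is meant among the compounds shown, and "the series" means these compounds.

compound 1 `Cn1cc(CNS(=O)(=O)c2ccccc2Nc2cc(-c3ccc4ccn(C)c4c3)c3nccnc3c2)cn1`: 0.267 h
compound 2 `CNC(=O)c1ccncc1Nc1cc(-c2ccc3ccn(C)c3c2)c2nccnc2c1`: 0.45 h
compound 3 `CN(C)C(=O)c1ccncc1Nc1cc(-c2ccc3ccn(C)c3c2)c2nccnc2c1`: 0.35 h

In an ADME assay on microsomes from liver (Mus musculus, strain CD-1) for metabolic stability, read by LC-MS, tested at 2 uM (on this read-out lower numbers stand for a shorter-lived compound and higher numbers for a longer-lived compound), compound 3 gives 0.35 h, within the scatter of both other compounds. Compound 4 `Cn1ccc2ccc(-c3cc(Nc4cnccc4C(=O)NCc4cncnc4)cc4nccnc34)cc21` changes one group: ((pyrimidin-5-yl)methyl)amino in place of dimethylamino on a carbonyl carbon. In words, ((pyrimidin-5-yl)methyl)amino stands in place of dimethylamino on a carbonyl carbon. Going by the values given here, only one measured step bears on this amide: a 1.3-fold lower number from compound 2 to compound 3 (0.11 log units; within the scatter), with methyl in place of hydrogen on an amide-type nitrogen. Among the compounds with values here, that swap is much smaller, so it offers only a loose guide, and no measured step brings in a new ring here. The expected step is a 1.2-fold lower number from compound 3 to compound 4 (0.07 log units; within the scatter), nothing beyond the scatter. For compound 4 the estimate is 0.3 h, with an expected range from 0.13 h to 0.7 h.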

Compound 4, half-life: 0.4 h
Beside the measured number, compound 4's estimate is 1.3-fold (0.12 log units) below it; the measured number falls inside the stated range.
By their numbers in this assay, from the lowest: compounds 1, 3, 4 and 2 (each within the scatter of the next).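

In this assay there is a 1.1-fold higher number from compound 3 to compound 4 (0.06 log units; within the scatter) when ((pyrimidin-5-yl)methyl)amino stands in place of dimethylamino on a carbonyl carbon. There is also a 1.1-fold lower number from compound 2 to compound 4 (0.05 log units; within the scatter) when pyrimidin-5-yl stands in place of hydrogen on a saturated chain carbon bound to an amide-type nitrogen. So this amide can carry a six-membered aromatic ring with no step beyond the scatter, which the small methyl swap between the earlier compounds could not show. On these data alone, whether an amine, a carboxylic acid or a longer chain in that place would give a step beyond the scatter stays open. Nothing measured here gives a reason for these results.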